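The source may report more compounds than this note shows. Statements on the series, on what has been measured and on what is new or still open speak of the compounds shown alone.

Compound 1 `O=C(Nc1cccc(Cl)c1)N[C@H]1CC[C@H](Oc2ccc(F)cc2)CC1` gives 5900 nM in a functional assay on CRL2813 cells (Homo sapiens) for cytotoxicity, read by sulforhodamine B assay, with a stated time of 5 days; a lower number here means a stronger inhibitor, a higher number a weaker inhibitor.
Compound 3 `O=C(Nc1ccccc1Br)N[C@H]1CC[C@H](Oc2ccc(F)cc2)CC1` gives 7700 nM in this assay.
Compound 2 `O=C(Nc1ccccc1I)N[C@H]1CC[C@H](Oc2ccc(F)cc2)CC1` reaches only the limit of > 20000 nM in this assay.

Compound 3 and compound 1 sit within the usual scatter of each other, as the step of a 1.3-fold higher number from compound 1 to compound 3 (0.12 log units; within the scatter) shows, while compound 2 gives no number, only a limit (the limit of > 20000 nM in this assay, at which 1 of the 3 values shown sits). The step from compound 3 to compound 4 `O=C(Nc1cccc(I)c1)N[C@H]1CC[C@H](Oc2ccc(F)cc2)CC1` is 3-iodophenyl in place of 2-bromophenyl on an amide-type nitrogen. Going by the values given here, two measured steps touch on it. The step of an at least 2.5-fold lower number from compound 2 to compound 3 (0.41 log units; beyond the scatter) shows that a bromo in place of an iodo on the aromatic carbon brought the number down from the limit, and the step of an at least 3.3-fold higher number from compound 1 to compound 2 (0.53 log units; beyond the scatter) went the other way, up to the limit. The step of a 1.3-fold higher number from compound 1 to compound 3 (0.12 log units; within the scatter) shows that moving from 3-chlorophenyl to 2-bromophenyl changed little. For compound 4 the halogen grows to iodine while the phenyl changes to 3-iodophenyl; the expected step of a 1.2-fold higher number from compound 3 to compound 4 (0.07 log units; within the scatter) is therefore small or modest upward, though the limit seen for compound 2 leaves it uncertain. Compound 4 is estimated at 9000 nM, with a range from 3500 nM to 25000 nM.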

Compound 4, half-maximal inhibitory concentration: 5200 nM
For compound 4 the middle estimate is 1.7-fold (0.24 log units) above the measured one; the measured number falls inside the stated range.
By their numbers in this assay, from the lowest: compounds 4, 1 and 3 (each within the scatter of the next). At a limit, above all of these: compound 2.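

Moved to 3-iodophenyl from 2-iodophenyl on the amide-type nitrogen, the same halogen gives an at least 3.8-fold lower number from compound 2 to compound 4 (0.58 log units; beyond the scatter), so among these two compounds iodine as such does not go with the weak result; its place on the phenyl does. Iodo in place of chloro on the aromatic carbon stays within the scatter, as a 1.1-fold lower number from compound 1 to compound 4 (0.05 log units; within the scatter) shows, and 3-iodophenyl in place of 2-bromophenyl also stays within it, as a 1.5-fold lower number from compound 3 to compound 4 (0.17 log units; within the scatter) shows. The contrast rests on a single compound, and compound 2 gives a limit rather than a number: the limit of > 20000 nM in this assay, at which 1 of the 4 values shown sits.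

The compounds shown leave open whether 3-bromophenyl or 2-chlorophenyl would follow the same split between the two places. They also leave open whether a non-halogen group on the phenyl, such as a methoxy, an amine or a carboxylic acid, would hold the number in this range.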